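A few compounds are considered here, and "the series" means these few. Any claim that something is new, unique, unknown or untested is made for them only; others in the source may bear on it.

Working notes on the series

Compound 1, `Cc1cc(NC(=O)Nc2ccc([N+](=O)[O-])c(C(F)(F)F)c2)c2ccccc2n1`, is known in an ADME assay on BJ cells (Homo sapiens) for cytotoxicity, with a stated time of 72 h (a higher number here means that more compound is needed for the effect, a lower number that less compound is needed), only by a limit: compound 1 gives > 25000 nM, which is a limit of this assay and not a number. Two analogues on the same core carry other groups. Compound 2, `COC(=O)c1ccc(NC(=O)Nc2cc(C)nc3ccccc23)cc1`, gives 21000 nM in this assay. Compound 3, `CSc1ccc(NC(=O)Nc2cc(C)nc3ccccc23)cc1`, gives > 25000 nM in this assay, again a limit. Among the measured compounds shown here, the one measured step, an at least 1.1-fold higher number from compound 2 to compound 3 (0.07 log units; that floor lies within the scatter) (methylsulfanyl in place of methoxycarbonyl on an aromatic carbon), stays within the scatter. All three values therefore sit at or near (the limit of > 25000 nM in this assay, at which 2 of the 3 values shown sit).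

Compound 4, `Cc1cc(NC(=O)Nc2cccc(C(F)(F)F)c2)c2ccccc2n1`, is not yet measured. It differs from compound 1 by hydrogen in place of nitro on an aromatic carbon. For the measured compounds named here, no measured step changes this position, so nothing recorded bears directly on it; the whole set is flat at the limit. Compound 4 is therefore expected to show no step beyond the scatter, a step that the limit leaves unreadable from compound 1 to compound 4, and most probably another limit. Compound 4 is estimated at 30000 nM, within 10000 nM to 100000 nM.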

Compound 4, half-maximal effective concentration: > 25000 nM
Compound 4 gave a limit, no number; the forecaster's own chance of this, stated with the estimate: 70%; the middle value does not contradict the limit.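

Compound 1 and compound 4 both stand at a limit in this assay, so no step can be read between them: the limit of > 25000 nM in this assay, at which 3 of the 4 values shown sit.

The compounds shown leave open whether hydrogen in place of nitro on an aromatic carbon changes the number in this assay at all.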